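A few compounds are considered here, and "the series" means these few. Any claim that something is new, unique, unknown or untested is made for them only; others in the source may bear on it.

Among the compounds with values here, in a functional assay on HMEC-1 cells (Homo sapiens) for antiproliferative activity, read by cell counting, with a stated time of 4 days (on this read-out higher numbers stand for weaker inhibition and lower numbers for stronger inhibition), compound 1 (`CC(Nc1ccccc1Oc1cccc(N)c1)=C1C(=O)CC(c2ccccc2)CC1=O`) gives 41 nM and compound 2 (`CC(Nc1ccccc1Oc1ccc(N)cc1)=C1C(=O)CC(c2ccccc2)CC1=O`) gives 47 nM, so compound 2 stands level with compound 1, the only other measured member of the series. Compound 3 (`COc1cccc(Oc2ccccc2NC(C)=C2C(=O)CC(c3ccccc3)CC2=O)c1`) comes next, and the change from compound 2 is 3-methoxyphenyl in place of 4-aminophenyl on an oxygen on an aromatic ring. In words, 3-methoxyphenyl stands in place of 4-aminophenyl on an oxygen on an aromatic ring. Within the data shown here, only one measured step bears on this: a 1.1-fold higher number from compound 1 to compound 2 (0.06 log units; within the scatter), which exchanges 3-aminophenyl for 4-aminophenyl at that same place. Among the measured compounds shown here, it compares two aminophenyl groups only, and no measured compound carries anything else there, so the data give weak guidance on a methoxyphenyl group. A modest move towards weaker inhibition is expected, with the estimated size being a 2.1-fold higher number from compound 2 to compound 3 (0.33 log units; beyond the scatter). In this assay the expected value for compound 3 is 100 nM, with an estimated range of 30 nM to 350 nM.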

Compound 3, half-maximal inhibitory concentration: 59 nM
Beside the measured number, compound 3's estimate is 1.7-fold (0.23 log units) above it, within the range that was stated.
By their numbers in this assay, from the lowest: compounds 1, 2 and 3 (each within the scatter of the next).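

In this assay, a 1.3-fold higher number from compound 2 to compound 3 (0.10 log units; within the scatter) and a 1.4-fold higher number from compound 1 to compound 3 (0.16 log units; within the scatter) show that this place on the oxygen accepts 3-methoxyphenyl as well as the two aminophenyl groups. The amino group is thus not required for a number in this range: 3-methoxyphenyl has 0 hydrogen-bond donors, whereas 4-aminophenyl has 1, and all three compounds remain within the scatter of one another. No supporting measurement is available to explain why the three numbers sit so closely together.

Still open, on these data alone, is whether the outer ring needs any added group at all, which an unsubstituted phenyl would test. As far as these compounds go, it is also open whether a carboxylic acid or a longer chain such as butoxy on that ring would give a step beyond the scatter.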